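Methoxy on the indole ring of a cyanoacrylate series

The compounds below may be only part of what the source reports. "The series", "measured", "known", "first", "only" and "open" are said of these compounds alone.

Of the compounds shown here, three have been measured in a functional assay on PC-3 cells (Homo sapiens) for cytotoxicity, read by WST assay, with a stated time of 24 h; a higher number here means a weaker inhibitor, a lower number a stronger inhibitor. Compound 1 `N#C/C(=C\c1c[nH]c2cc(F)ccc12)C(=O)c1c[nH]c2ccccc12` carries a fluoro group; in this assay compound 1 reaches only the limit of > 50000 nM. Compound 3 `N#C/C(=C\c1c[nH]c2ccccc12)C(=O)c1c[nH]c2ccccc12` is the unsubstituted parent; in this assay compound 3 likewise reaches only the limit of > 50000 nM. Compound 2 `COc1ccc2c(/C=C(\C#N)C(=O)c3c[nH]c4ccccc34)c[nH]c2c1` gives a measurable value in this assay, 33300 nM. The two cores of compound 3 and compound 1 differ by fluoro in place of hydrogen on an aromatic carbon; this gives a step that the two limits leave unreadable from compound 1 to compound 3. From compound 3 to compound 2 the change is methoxy in place of hydrogen on an aromatic carbon, and it gives an at least 1.5-fold lower number from compound 3 to compound 2 (0.17 log units; that floor lies within the scatter). The corresponding comparison of compound 1 with compound 2 gives an at least 1.5-fold lower number from compound 1 to compound 2 (0.17 log units; that floor lies within the scatter). Both of these steps start from the limit of > 50000 nM in this assay, at which 2 of the 3 values shown sit, so their true size is not known.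

Compound 4 `COc1ccc2c(C(=O)/C(C#N)=C/c3c[nH]c4cc(F)ccc34)c[nH]c2c1` has not yet been measured in this assay. It differs from compound 1 by methoxy in place of hydrogen on an aromatic carbon, the same change that was made from compound 3 to compound 2. He expects this change on compound 1 to give an at least 1.4-fold lower number from compound 1 to compound 4 (0.15 log units; that floor lies within the scatter), resting on the step from compound 3 to compound 2 of an at least 1.5-fold lower number from compound 3 to compound 2 (0.17 log units; that floor lies within the scatter), whose size is only a floor. His estimate for compound 4 in this assay is 35000 nM, between 15000 nM and 80000 nM.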

Compound 4, half-maximal inhibitory concentration: 36000 nM
Compound 4: the middle estimate sits 1.0-fold (0.01 log units) below what was measured, and the stated range covers the measured number.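

Carried onto the fluoro-bearing core of compound 1, methoxy in place of hydrogen on an aromatic carbon gives, in this assay, an at least 1.3-fold lower number from compound 1 to compound 4 (0.14 log units; that floor lies within the scatter). The result therefore shows that the change gives a lower number on both cores, with the two steps standing side by side as follows: the same change on two cores in this assay, an at least 1.5-fold lower number (0.17 log units; that floor lies within the scatter) from compound 3 to compound 2 and an at least 1.3-fold lower number (0.14 log units; that floor lies within the scatter) from compound 1 to compound 4; the limit leaves it open whether they differ It does not show how large either step is, or whether the change has the same size on the two cores, since each step starts from a limit and not from a number: the limit of > 50000 nM in this assay, at which 2 of the 4 values shown sit.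

The compounds shown leave open whether another group on the same aromatic carbon, such as an amine, a hydroxyl or an ethoxy chain, would carry over between the two cores as methoxy does here. They also leave open whether a core whose parent gives a measured number rather than a limit would allow the true size of the methoxy step to be read.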